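Phenyl in Place of Chloro: What Cytotoxicity Is Expected

A few compounds are considered here, and "the series" means these few. Any claim that something is new, unique, unknown or untested is made for them only; others in the source may bear on it.

Compound 1 `COc1ccc2nc(C)cc(OCC(=O)Nc3ccccc3)c2c1` is the plain member of this small set. In an ADME assay on HepG2 cells (Homo sapiens) for cytotoxicity, read by trypan blue exclusion, with a stated time of 48 h, in the presence of a further agent that is not named here (on this read-out higher numbers stand for lower toxicity in this test and lower numbers for higher toxicity in this test), compound 1 gives 118000 nM. Compound 2 `COc1ccc(NC(=O)COc2cc(C)nc3ccc(OC)cc23)cc1` carries a methoxy group on the aromatic carbon where compound 1 has hydrogen. For compound 2 this assay reports only a limit, > 142000 nM, not a number. Compound 3 `COc1ccc2nc(C)cc(OCC(=O)Nc3ccc(Cl)cc3)c2c1` instead carries chloro at that carbon, and in this assay compound 3 gives 71100 nM. Of the two plain numbers, that of compound 3 sits nearest compound 1, separated by a 1.7-fold lower number from compound 1 to compound 3 (0.22 log units; within the scatter). The methoxy step an at least 1.2-fold higher number from compound 1 to compound 2 (0.08 log units; that floor lies within the scatter) and the chloro-for-methoxy step an at least 1.9-fold lower number from compound 2 to compound 3 (0.30 log units; that floor lies within the scatter) are likewise within the scatter, and the limit of > 142000 nM in this assay, at which 1 of the 3 values shown sits, caps what compound 2 can show.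

Compound 4 `COc1ccc2nc(C)cc(OCC(=O)Nc3ccc(-c4ccccc4)cc3)c2c1` differs from compound 3 by phenyl in place of chloro on an aromatic carbon. Both earlier changes at this carbon, hydrogen to chloro and methoxy to chloro, moved the number by less than the scatter, so a further swap at the same place is expected to do little in this assay. Compound 4 is therefore estimated at 60000 nM, within 25000 nM to 140000 nM. That estimate means a step of a 1.2-fold lower number from compound 3 to compound 4 (0.07 log units; within the scatter), expected to stay within the scatter.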

Compound 4, half-maximal cytotoxic concentration: > 126000 nM
Compound 4 was reported as a limit; the forecaster's own chance of this, stated with the estimate: 10%; at least 2.1-fold (0.32 log units) between middle value and limit.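

Phenyl puts a whole six-membered aromatic ring, six heavy atoms, on the carbon that held a single chlorine in compound 3, and the result is an at least 1.7-fold higher number from compound 3 to compound 4 (0.24 log units; that floor lies within the scatter). So in this assay this carbon now carries a far larger group than hydrogen, chloro or methoxy, with no sign of a lower number, which would have meant higher toxicity in this test. Measured against the plain hydrogen of compound 1, the same group gives an at least 1.0-fold higher number from compound 1 to compound 4 (0.02 log units; that floor lies within the scatter), and the reading for compound 4 is a limit rather than a number, as is the reading for compound 2, so the step between these two cannot be read: the limit of > 126000 nM in this assay, at which 1 of the 4 values shown sits.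

From the compounds shown here alone, how far the number for compound 4 really lies from those of compound 1 and compound 3 stays open, since a limit fixes only one side of it. Also open is how this assay would read with an amine, a carboxylic acid or a longer chain on this same carbon, as all the groups shown there are hydrogen, chloro, methoxy and phenyl.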